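A few compounds are considered here, and "the series" means these few. Any claim that something is new, unique, unknown or untested is made for them only; others in the source may bear on it.

Measured so far in a functional assay on A549 cells (Homo sapiens) for inhibition, read by sulforhodamine B assay, tested at 100 uM; on this read-out lower numbers stand for less inhibition of growth and higher numbers for more inhibition of growth at the one concentration tested:
- compound 1 `CC(=O)N1N=C(c2ccc(OCc3cn(Cc4ccc([N+](=O)[O-])cc4)nn3)cc2)CC1c1ccccc1`: 80%
- compound 2 `COc1cc(C2CC(c3ccc([N+](=O)[O-])cc3)=NN2C(C)=O)ccc1OCc1cn(Cc2ccc([N+](=O)[O-])cc2)nn1`: 72%

Compound 2 gives the smaller of the two numbers in this assay, but its gap to compound 1 lies within the scatter, so the two cannot be ranked against each other. Compound 3 `COc1ccc(C2=NN(C(C)=O)C(c3ccc(OCc4cn(Cc5ccc([N+](=O)[O-])cc5)nn4)c(OC)c3)C2)cc1` is not yet measured. It differs from compound 2 in one place: methoxy in place of nitro on an aromatic carbon. Among the measured compounds shown here, no step between measured compounds covers this exchange, and nothing in the two values speaks to it. The expectation therefore rests on the fact that both measured compounds sit close together in this assay; the step from compound 2 to compound 3 is expected to be small, a number 4 percentage points lower from compound 2 to compound 3 (within the scatter), and most likely not beyond the scatter in either direction. Compound 3 is accordingly estimated at 68%, with a range from 45% to 85%.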

Compound 3, percent growth inhibition at one concentration: 84%
The estimate for compound 3 lay 16 percentage points below the measured number, and the stated range covers the measured number.
By their numbers in this assay, from the lowest: compounds 2, 1 and 3 (each within the scatter of the next, the first and the last beyond it).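

Among the compounds shown here, the exchange of 4-nitrophenyl for 4-methoxyphenyl in this assay gives a number 12 percentage points higher from compound 2 to compound 3 (beyond the scatter) and is the first step that can be read, so the group on this aromatic carbon, para to a large group, can register in growth inhibition at the one concentration tested. The step is modest and rests on a single pair of compounds, so it gives a direction for this pair and no general trend. No measurement bears on what lies behind this step.

The compounds shown leave open whether an amine, a hydroxyl or a carboxylic acid on this carbon would give a number nearer to that of compound 2 or compound 3, and whether a longer alkoxy chain would extend the step. They also leave open whether the same exchange would give a similar step on a different core.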